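Thiazolyl ketone pyrimidinone series: chloro added on the phenyl

The source may report more compounds than this note shows. Statements on the series, on what has been measured and on what is new or still open speak of the compounds shown alone.

Measured so far:
compound 1 `Cc1nc(-c2ccc(Cl)cc2)sc1C(=O)CSc1nc(-c2cccc(Cl)c2)c(C#N)c(=O)[nH]1` gives 95.2%
compound 2 `COc1ccc(-c2nc(SCC(=O)c3sc(-c4ccccc4)nc3C)[nH]c(=O)c2C#N)cc1OC` gives 69.8%

In a functional assay on U-87MG ATCC cells for antiproliferative activity against U-87 MG (Homo sapiens), read by MTT assay, with a stated time of 48 h, tested at 10 uM (a lower number here means a stronger effect, a higher number a weaker effect of the compound at the concentration tested), compound 2 stands as the lower of the two numbers, with compound 1 a distance above it that is beyond the scatter. For the measured compounds named here, the two compounds differ at more than one place, so no single step is counted between them; their values show only that compound 2 has the stronger effect of the pair.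

Compound 3 `COc1ccc(-c2nc(SCC(=O)c3sc(-c4ccc(Cl)cc4)nc3C)[nH]c(=O)c2C#N)cc1OC` is not yet measured. It differs from compound 2 by chloro in place of hydrogen on an aromatic carbon. Going by the values given here, no measured pair isolates this change; compound 1 carries the same 4-chlorophenyl together with other differences and cannot be read as a step. The step from compound 2 to compound 3 is expected to be small, a number 8.2 percentage points higher from compound 2 to compound 3 (within the scatter), toward a weaker effect if any, possibly within the scatter. Compound 3 is expected to give 78%, with a range from 55% to 98%.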

Compound 3, a percentage reported as activity, at one concentration (the size of the read-out at that concentration, not a potency): 83.3%
Estimate against measurement, compound 3: 5.3 percentage points below, and the stated range covers the measured number.
By their numbers in this assay, from the lowest: compound 2; then compound 3; then compound 1.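

In this assay, for the compounds shown here, the change from phenyl to 4-chlorophenyl gives a number 13.5 percentage points higher from compound 2 to compound 3 (beyond the scatter) and so isolates this position for the first time, with chloro moving the read-out toward a weaker effect beyond the scatter. With the 4-chlorophenyl held constant, the second site also responds: 3,4-dimethoxyphenyl in place of 3-chlorophenyl gives a number 11.9 percentage points lower from compound 1 to compound 3 (beyond the scatter) toward a stronger effect, also beyond the scatter. No measured evidence bears on either step, so the data give no explanation for them.

Going by these compounds, whether the weaker effect is particular to chloro remains open; fluoro, methoxy or an amine on the same aromatic carbon would test this. Both steps rest on a single concentration, so whether the stronger and weaker effects seen there would hold at other concentrations is also unresolved.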